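The source may report more compounds than this note shows. Statements on the series, on what has been measured and on what is new or still open speak of the compounds shown alone.

Series notes, step from compound 2 to compound 4. Compound 1 `Cc1cccc(C#Cc2ccc3c(n2)CCN(C(C)C)C3=O)c1` gives 510 nM in an assay on HEK293 cells for displacement of a labelled ligand from metabotropic glutamate receptor 5 (Homo sapiens), with a stated time of 2 h; a lower number here means a stronger inhibitor, a higher number a weaker inhibitor. Compound 3 `CC(C)N1CCc2nc(C#Cc3ccccn3)ccc2C1=O` gives 2740 nM. Compound 2 `CC(C)N1CCc2nc(C#Cc3ccc(Cl)cc3)ccc2C1=O` gives 27100 nM, the highest of the three numbers: the step of a 53-fold higher number from compound 1 to compound 2 (1.73 log units; beyond the scatter) and the step of a 9.9-fold lower number from compound 2 to compound 3 (1.00 log units; beyond the scatter) both place compound 2 at the weak end. Compound 4 `O=C1c2ccc(C#Cc3ccc(Cl)cc3)nc2CCN1C1CCCC1` carries the change (cyclopentyl in place of isopropyl on an amide-type nitrogen in a ring). For the measured compounds named here, every measured step in this set alters the group on the triple-bonded carbon; none touches the amide-type nitrogen in the ring, so no step bears directly on this change. For compound 4 a step in this assay of a 1.4-fold lower number from compound 2 to compound 4 (0.13 log units; within the scatter) is therefore expected, within the scatter. Compound 4 is estimated at 20000 nM, with a range of 6000 nM to 60000 nM.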

Compound 4, inhibition constant: > 32000 nM
Compound 4 ended at the assay's limit; the forecaster's own chance of this, stated with the estimate: 10%; middle value at least 1.6-fold (0.20 log units) away from the limit.
By their numbers in this assay, from the lowest: compound 1; then compound 3; then compound 2. At a limit, above all of these: compound 4.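

In this assay compound 4 gives > 32000 nM, a limit of the assay and not a number. For the compounds shown here, this is the first reading at the amide-type nitrogen in a ring, and an at least 1.1-fold higher number from compound 2 to compound 4 (0.07 log units; that floor lies within the scatter): with 4-chlorophenyl on the triple-bonded carbon, cyclopentyl in place of isopropyl shows no gain in binding. How far compound 4 lies past that limit cannot be read.

Open, as far as these compounds go, is whether cyclopentyl costs binding alongside the 3-methylphenyl of compound 1, where a loss could be read. Also open, from the compounds shown here alone, is how a methyl group or a chain ending in an amine would behave on that nitrogen.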